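This account rests on a few compounds, and the source may have more. Where it says the series, first, only, none or still open, it means among the compounds named here.

Of the compounds shown here, three of this set have been measured in a functional assay on MDA-MB-435S cells (Homo sapiens) for antiproliferative activity, read by MTT assay, with a stated time of 72 h; on this read-out lower numbers stand for stronger inhibition and higher numbers for weaker inhibition. Compound 1 `COc1ccc2occ(CSC(=S)N3CCCCC3)c(=O)c2c1` gives 930 nM in this assay. Compound 2 `COc1ccc2occ(CSC(=S)N3CCCC3)c(=O)c2c1`, which carries pyrrolidin-1-yl in place of piperidin-1-yl on a thiocarbonyl carbon, gives 1800 nM, and the step of a 1.9-fold higher number from compound 1 to compound 2 (0.29 log units; within the scatter) is within the scatter. Compound 3 `CCOC(=O)c1cc(=O)c2cc(CSC(=S)N(C(C)C)C(C)C)ccc2o1`, built on a different core, gives 8100 nM. On these numbers compound 2 stands second highest of the three, with compound 1 nearest and compound 3 furthest.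

The new compound 4 `COc1ccc2occ(CSC(=S)N3CCOCC3)c(=O)c2c1` differs from compound 2 in one place: morpholin-4-yl in place of pyrrolidin-1-yl on a thiocarbonyl carbon. Within the data shown here, the only measured step that bears on this kind of change is the swap of one non-aromatic ring for another on the thiocarbonyl carbon, a 1.9-fold higher number from compound 1 to compound 2 (0.29 log units; within the scatter), which stayed within the scatter. Morpholin-4-yl again puts a six-membered non-aromatic ring there, now with a second hetero atom, and nothing measured here tells how that added oxygen acts. For compound 4 the expected step of a 1.1-fold higher number from compound 2 to compound 4 (0.05 log units; within the scatter) is therefore none beyond the scatter in this assay. Compound 4 is estimated at 2000 nM, with a range from 800 nM to 5000 nM.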

Compound 4, half-maximal inhibitory concentration: > 40000 nM
Compound 4: a limit, no number; the forecaster's own chance of this, stated with the estimate: 5%; middle value at least 20-fold (1.30 log units) from the limit.
By their numbers in this assay, from the lowest: compounds 1 and 2 (each within the scatter of the next); then compound 3. At a limit, above all of these: compound 4.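

The result for compound 4 in this assay is a limit of the assay and not a number: the limit of > 40000 nM in this assay, at which 1 of the 4 values shown sits. Until now the group on the thiocarbonyl carbon seemed to tolerate change, since swapping one ring for another gave only a 1.9-fold higher number from compound 1 to compound 2 (0.29 log units; within the scatter), but this position proves far more sensitive, with morpholin-4-yl giving an at least 22-fold higher number from compound 2 to compound 4 (1.34 log units; beyond the scatter) and an at least 43-fold higher number from compound 1 to compound 4 (1.63 log units; beyond the scatter). Compound 1 and compound 4 both carry a six-membered non-aromatic ring there and differ only in the ring oxygen of morpholin-4-yl, so ring size alone cannot account for this large step, and a small change in the ring's atoms can separate a compound active in this test from one that reaches the limit.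

Going by these compounds, whether this drop is specific to oxygen stays open: thiomorpholin-4-yl, with a sulfur atom in place of that oxygen, or piperazin-1-yl, with an amine there, would help to settle it. On these data alone, it is also open whether morpholin-4-yl has the same effect on the different core of compound 3, which carries an open-chain diisopropylamino group in that place.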